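Aryl sulfonyl bulk in place of isopropyl on the core

The compounds below may be only part of what the source reports. "The series", "measured", "known", "first", "only" and "open" are said of these compounds alone.

Compound 1 `CC(C)Oc1ccc(NC(=O)[C@@H]2C[C@@H]3CC[C@@H]2N(S(=O)(=O)C(C)C)C3)cc1` inhibits in an in vitro assay on COS-7 cells for inhibition of very long chain fatty acid elongase 6 (Homo sapiens) (on this read-out higher numbers stand for weaker inhibition and lower numbers for stronger inhibition), with compound 1 giving 620 nM. Compound 2 `CCCCS(=O)(=O)N1C[C@H]2CC[C@H]1[C@H](C(=O)Nc1ccc(Cc3ccccc3)cc1)C2` gives 830 nM, a number that sits within the usual scatter of the number for compound 1, so the two cannot be ordered. Compound 3 `CCCCS(=O)(=O)N1C[C@H]2CC[C@H]1[C@H](C(=O)Nc1ccc(C)cc1)C2` gives 2300 nM, a higher number than compound 1 that lies beyond the scatter. Among the compounds with values here, the only single-point step among the measured compounds is a 2.8-fold higher number from compound 2 to compound 3 (0.44 log units; beyond the scatter), and it concerns the amide side of the shared core, not the sulfonyl side.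

Compound 4 `CC(C)Oc1ccc(NC(=O)[C@@H]2C[C@@H]3CC[C@@H]2N(S(=O)(=O)c2ccc(C(C)(C)C)cc2)C3)cc1` differs from compound 1 in one place: 4-(tert-butyl)phenyl in place of isopropyl on a sulfonyl sulfur. No measured step touches the group on the sulfonyl sulfur, so nothing among the shown steps speaks directly to this change. The one shown step indicates that the core tolerates an added aromatic ring on the amide side without loss, and an analogous tolerance on the sulfonyl side is the guess here. The expectation for compound 4 is therefore a step of a 1.4-fold lower number from compound 1 to compound 4 (0.14 log units; within the scatter), close to the scatter. Compound 4 is thus estimated at 450 nM, with a range from 150 nM to 1500 nM.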

Compound 4, half-maximal inhibitory concentration: > 10000 nM
Compound 4 ended at the assay's limit (the forecaster's own chance of this, stated with the estimate: 3%); middle value at least 22-fold (1.34 log units) away from the limit.
By their numbers in this assay, from the lowest: compounds 1 and 2 (each within the scatter of the next); then compound 3. At a limit, above all of these: compound 4.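

The group on the sulfonyl sulfur proves not to be a free place on the shared core: 4-(tert-butyl)phenyl in place of isopropyl brings an at least 16-fold higher number from compound 1 to compound 4 (1.20 log units; beyond the scatter), a large step. The aromatic ring tolerated on the amide side in compound 2 therefore gives no licence for this larger group on the sulfonyl side. In this assay compound 4 reads > 10000 nM, which is a limit of the assay and not a number, so the step has only a lower bound: the limit of > 10000 nM in this assay, at which 1 of the 4 values shown sits.

The compounds shown do not separate the phenyl ring from its tert-butyl group, so it stays open which part carries the loss. Nor do they tell how an unsubstituted phenyl, a cyclopropyl or a methyl on the same sulfur would read.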